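Acetamido Enters the Sulfonyl Phenyl of Compound 2

This account rests on a few compounds, and the source may have more. Where it says the series, first, only, none or still open, it means among the compounds named here.

Compound 2 `O=C1/C(=C/c2ccc(F)cc2)CN(S(=O)(=O)c2ccccc2)C/C1=C\c1ccc(F)cc1` and compound 1 `O=C1/C(=C/c2cccc(F)c2)CN(S(=O)(=O)c2ccc(F)cc2)C/C1=C\c1cccc(F)c1` were both run in a functional assay on SMMC-7721 cells (Homo sapiens) for cytotoxicity, read by MTT assay, with a stated time of 24 h; a lower number here means a stronger inhibitor, a higher number a weaker inhibitor. Compound 2 gives 9100 nM, the lower of the two numbers shown, while compound 1 gives 13500 nM; the gap between them lies within the usual scatter, so neither is called the stronger. Compound 3 `CC(=O)Nc1ccc(S(=O)(=O)N2C/C(=C\c3ccc(F)cc3)C(=O)/C(=C/c3ccc(F)cc3)C2)cc1` is not yet measured. It differs from compound 2 by acetamido in place of hydrogen on an aromatic carbon. For the measured compounds named here, no measured pair shows a step of this kind, so compound 3 is expected to stay near compound 2, with a 1.0-fold lower number from compound 2 to compound 3 (0.00 log units; within the scatter) expected to fall within the scatter. Compound 3 is estimated at 9000 nM, expected between 4000 nM and 20000 nM.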

Compound 3, half-maximal inhibitory concentration: 9800 nM
The estimate for compound 3 lay 1.1-fold (0.04 log units) below the measured number, and the stated range covers the measured number.
By their numbers in this assay, from the lowest: compounds 2, 3 and 1 (each within the scatter of the next).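

In this assay, acetamido on this aromatic carbon, para to a large group, gives a 1.1-fold higher number from compound 2 to compound 3 (0.03 log units; within the scatter), so this position takes the added group with no step beyond the scatter. Compound 1 and compound 2 differ in more than one place, so neither could show this for the position alone. Nothing available explains this result. From the compounds shown here alone, whether an amine, a carboxylic acid or a longer chain at this position would also stay within the scatter of compound 2 remains open.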